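Notes on replacing the sulfonyl substituent of compound 1

The source may report more compounds than this note shows. Statements on the series, on what has been measured and on what is new or still open speak of the compounds shown alone.

Of the compounds shown here, two have numbers so far. In an ADME assay on microsomes from liver (Homo sapiens) for metabolic stability, read by LC-MS, using NADPH, with a stated time of 30 min, tested at 0.1 uM (a lower number here means that less of the compound is left, a higher number that more of the compound is left), compound 1 (`O=S(=O)(NCC1COC1)c1cccc(-c2ccc3nccc(-c4ccncc4)c3n2)c1`) gives 2%, the lower of the two values. Compound 2 (`NS(=O)(=O)c1ccc(-c2ccc3nccc(-c4ccncc4)c3n2)cc1`) gives 76%, and the gap between them lies well beyond the scatter. For the measured compounds named here, these two compounds differ in more than one place, so no measured step isolates a single change.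

The next compound is compound 3 (`C[C@@H]1CN(S(=O)(=O)c2cccc(-c3ccc4nccc(-c5ccncc5)c4n3)c2)C[C@H](C)N1`), which keeps the core of compound 1. The change is 3,5-dimethylpiperazin-1-yl in place of ((oxetan-3-yl)methyl)amino on a sulfonyl sulfur.

Going by the values given here, no measured pair shows what this replacement does, so the expectation remains loose. Compound 1 at 2% leaves almost no room for a fall, and compound 2 at 76% shows that a much higher number is reachable with the shared core. An upward move beyond the scatter is therefore expected, with an estimated size of a number 28 percentage points higher from compound 1 to compound 3 (beyond the scatter). In this assay, compound 3 is expected at 30%, with an estimated range of 6% to 68%.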

Compound 3, percent of the compound remaining: 34%
Estimate against measurement, compound 3: 4 percentage points below, within the range that was stated.
By their numbers in this assay, from the lowest: compound 1; then compound 3; then compound 2.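

For the compounds shown here, with the shared core held constant, 3,5-dimethylpiperazin-1-yl in place of ((oxetan-3-yl)methyl)amino on a sulfonyl sulfur goes with a number 32 percentage points higher from compound 1 to compound 3 (beyond the scatter) in this assay and gives the first measured step that isolates a single change. The low number of compound 1 is therefore not set by the shared core alone, and this position on the sulfonyl sulfur can move the read-out by a large amount. The ring size, the heavy-atom count, the hetero atoms and the defined stereocentres all change in this one step, and no measurement available here explains the rise or assigns it to any one of these differences.

As far as these compounds go, it remains open whether the piperazine ring or its two methyl groups account for the step, and whether the defined stereocentres of compound 3 contribute to it. An unsubstituted piperazin-1-yl, a morpholin-4-yl or a simple dimethylamino group on the same sulfonyl sulfur would help separate these contributions and show how far the number in this assay can move at this position.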